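Aryl substituent variation in the amide series against UFO

This account rests on a few compounds, and the source may have more. Where it says the series, first, only, none or still open, it means among the compounds named here.

Among the measured compounds shown here, compound 2 `Cn1cc(-c2ccc(NC(=O)c3cn(CC4CCOCC4)cc(-c4ccc(Cl)cc4)c3=O)cc2)c2c(N)ncnc21` in an assay on isolated protein for inhibition of tyrosine-protein kinase receptor UFO (Homo sapiens), read by ELISA (a lower number here means a stronger inhibitor, a higher number a weaker inhibitor), gives 0.2 nM, the lowest of the two numbers so far; the nearest is compound 1 `Cn1cc(-c2ccc(NC(=O)c3cn(CC4CCOCC4)cc(-c4ccc(F)cc4F)c3=O)cc2)c2c(N)ncnc21`, which in this assay gives 0.8 nM, a difference of a 4.0-fold lower number from compound 1 to compound 2 (0.60 log units; beyond the scatter). Compound 3 `Cn1cc(-c2ccc(NC(=O)c3cn(CC4CCOCC4)cc(-c4ccccc4)c3=O)cc2)c2c(N)ncnc21` differs from compound 2 by hydrogen in place of chloro on an aromatic carbon. For the measured compounds named here, only the step from compound 1 to compound 2 bears on this change, and only indirectly, since it exchanged one substituted phenyl for another. Compound 3 is therefore expected to move by about a 2.5-fold higher number from compound 2 to compound 3 (0.40 log units; beyond the scatter), toward a somewhat higher number. The estimate for compound 3 is 0.5 nM, within 0.15 nM to 1.6 nM.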

Compound 3, half-maximal inhibitory concentration: 1 nM
Beside the measured number, compound 3's estimate is 2.0-fold (0.30 log units) below it; low and high end bracket the measured number.
By their numbers in this assay, from the lowest: compound 2; then compounds 1 and 3 (each within the scatter of the next).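

In this assay, the step of a 5.0-fold higher number from compound 2 to compound 3 (0.70 log units; beyond the scatter) ties the low number of compound 2 to the single chloro on the phenyl ring, now measured directly against hydrogen. The step of a 1.3-fold higher number from compound 1 to compound 3 (0.10 log units; within the scatter) separates the 2,4-difluorophenyl from plain phenyl by no more than the usual scatter, so the advantage belongs to 4-chlorophenyl alone among these three aryl groups. Nothing measured here explains this difference. Open, from the compounds shown here alone, is whether bromo, methoxy or an amine in place of the chloro would keep the number as low, and whether a single fluorine there would behave like chloro or like hydrogen.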